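Moving a methyl group on the pendant ring: expected cytotoxicity

A few compounds are considered here, and "the series" means these few. Any claim that something is new, unique, unknown or untested is made for them only; others in the source may bear on it.

Measured compounds:
compound 1: `Cc1ccccc1-c1cc(C)c(Nc2ccnc(Nc3ccc(C#N)cc3)n2)c(C)c1` — 3820 nM
compound 2: `Cc1cc(-c2cc(Cl)cc(Cl)c2)cc(C)c1Nc1ccnc(Nc2ccc(C#N)cc2)n1` — 4290 nM

Both compounds were tested in an ADME assay on MT4 cells (Homo sapiens) for cytotoxicity, read by MTT assay, with a stated time of 4 days; on this read-out higher numbers stand for lower toxicity in this test and lower numbers for higher toxicity in this test. Compound 1 gives 3820 nM, and compound 2 gives 4290 nM. The step of a 1.1-fold higher number from compound 1 to compound 2 (0.05 log units; within the scatter) lies within the scatter, so the two cannot be told apart on these numbers; compound 1 has the lower of the two numbers only by a margin that means nothing here.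

Compound 3, `Cc1cccc(-c2cc(C)c(Nc3ccnc(Nc4ccc(C#N)cc4)n3)c(C)c2)c1`, differs from compound 1 in one place: 3-methylphenyl in place of 2-methylphenyl on an aromatic carbon. Going by the values given here, the only measured step, from compound 1 to compound 2, swapped the whole pendant ring for a different one and still gave no movement beyond the scatter. The change to compound 3 is smaller: the same atoms, only a methyl group moved along the ring. No measured step bears on this exact move, so the expectation rests on the one step shown.

Compound 3 is therefore expected to give a number in this assay close to that of compound 1, with a step of a 1.0-fold higher number from compound 1 to compound 3 (0.02 log units; within the scatter) that stays within the scatter. The estimate for compound 3 is 4000 nM, with a range from 2000 nM to 8000 nM.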

Compound 3, half-maximal cytotoxic concentration: 3670 nM
Compound 3: the middle estimate sits 1.1-fold (0.04 log units) above what was measured; low and high end bracket the measured number.
By their numbers in this assay, from the lowest: compounds 3, 1 and 2 (each within the scatter of the next).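

In this assay, moving the methyl group from 2-methylphenyl to 3-methylphenyl gives a 1.0-fold lower number from compound 1 to compound 3 (0.02 log units; within the scatter) and so leaves the two placements of the methyl group on the pendant ring impossible to tell apart. Going back to the other pendant ring, 3-methylphenyl in place of 3,5-dichlorophenyl gives a 1.2-fold lower number from compound 2 to compound 3 (0.07 log units; within the scatter) and so places all three compounds within the scatter of one another, which means that none of these three rings, on the aromatic carbon meta to two methyl groups and para to a large group, stands out on this read-out. No measurement is at hand that could explain this even picture.

On these data alone, all three compounds carry a substituted phenyl ring at this carbon, so whether an amine or a carboxylic acid on that ring, or a longer chain in place of the ring, would move the number beyond the scatter remains open. As far as these compounds go, it is also open whether the three compounds would stay as close together on any read-out other than this cytotoxicity test.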